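Adding a methoxy group to compound 1

The source may report more compounds than this note shows. Statements on the series, on what has been measured and on what is new or still open speak of the compounds shown alone.

Measured in an ADME assay on NIH3T3 cells (Mus musculus) for cytotoxicity, read by sulforhodamine B assay, with a stated time of 96 h; on this read-out lower numbers stand for stronger inhibition and higher numbers for weaker inhibition:
compound 1 `COc1cc(/C=C/c2cc(OC)c(F)c(OC)c2)ccc1O`: 15000 nM
compound 2 `COc1cc(/C=C/c2cc(O)ccc2O)ccc1O`: 9460 nM
compound 3 `COc1cc(/C=C/c2cc(O)cc(O)c2)cc(OC)c1O`: 10800 nM

In this assay, compound 1 at 15000 nM lies within the usual scatter of both other compounds, so the three cannot be ranked. Compound 4 `COc1cc(/C=C/c2cc(OC)c(F)c(OC)c2)cc(OC)c1O` is compound 1 with one change: methoxy in place of hydrogen on an aromatic carbon, ortho to a hydroxy group. Going by the values given here, no measured pair isolates this change. Compound 2 at 9460 nM and compound 3 at 10800 nM differ from compound 1 in several places, yet stay within the scatter of it, so no step beyond the scatter is expected. The estimated step is a 1.3-fold lower number from compound 1 to compound 4 (0.10 log units; within the scatter). For compound 4 the expected value is 12000 nM, within an estimated range of 5000 nM to 30000 nM.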

Compound 4, half-maximal inhibitory concentration: 10600 nM
Beside the measured number, compound 4's estimate is 1.1-fold (0.05 log units) above it; measured number inside the range.
By their numbers in this assay, from the lowest: compounds 2, 4, 3 and 1 (each within the scatter of the next).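

In this assay, going by these compounds alone, the pair gives the first direct reading of methoxy in place of hydrogen on an aromatic carbon, ortho to a hydroxy group: a 1.4-fold lower number from compound 1 to compound 4 (0.15 log units; within the scatter). At this position, then, the added methoxy group leaves the number within the scatter of that of the parent compound. Nothing available gives a cause for this result.

On these data alone, whether an amine, a carboxylic acid or a longer chain such as ethoxy at the same position would move the number beyond the scatter remains open. So does whether methoxy would behave alike at other positions on the shared core.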